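The source may report more compounds than this note shows. Statements on the series, on what has been measured and on what is new or still open speak of the compounds shown alone.

Compounds measured in a functional assay on MCF7 cells (Homo sapiens) for antiproliferative activity, read by MTT assay, with a stated time of 24 h, tested at 12.5 uM; on this read-out higher numbers stand for a weaker effect at the one concentration tested and lower numbers for a stronger effect:
- compound 1 `OC(CCn1nc2c(Br)c(Br)c(Br)c(Br)c2n1)c1ccc(Br)cc1` gives 82%
- compound 2 `OC(CCn1nc2c(Br)c(Br)c(Br)c(Br)c2n1)c1ccccc1` gives 115%
- compound 3 `C[C@@H](O)CCn1nc2c(Br)c(Br)c(Br)c(Br)c2n1` gives 109%

Compound 2 gives the highest of the three numbers in this assay, but only the gap to compound 1 is beyond the scatter; the gap to compound 3 is within it. The next compound, compound 4 `OC(CCn1nc2c(Br)c(Br)c(Br)c(Br)c2n1)c1cccc(Br)c1`, differs from compound 2 in one place: bromo in place of hydrogen on an aromatic carbon.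

Among the compounds with values here, one measured step bears on this. It runs the opposite way, hydrogen in place of bromo on an aromatic carbon, and gave a number 33 percentage points higher from compound 1 to compound 2 (beyond the scatter). Adding a bromo to that ring, though on a different carbon, may therefore pull the number down by a comparable amount, yet a single step with the bromo elsewhere is thin ground, so the expectation carries wide uncertainty.

Compound 4 is expected to give about 88%, within a range from 65% to 112%. The expected step is then a number 27 percentage points lower from compound 2 to compound 4 (beyond the scatter).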

Compound 4, a percentage reported as activity, at one concentration (the size of the read-out at that concentration, not a potency): 81%
For compound 4 the middle estimate is 7 percentage points above the measured one; low and high end bracket the measured number.
By their numbers in this assay, from the lowest: compounds 4 and 1 (each within the scatter of the next); then compounds 3 and 2 (each within the scatter of the next).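

The change from phenyl to 3-bromophenyl gives a number 34 percentage points lower from compound 2 to compound 4 (beyond the scatter) in this assay, and a lower number here means a stronger effect at the one concentration tested. Moving the bromo to the other ring carbon makes little difference, with a number 1 percentage points lower from compound 1 to compound 4 (within the scatter) and so no separation between the two placements, which means that in these compounds a bromo on this ring matters more than which of the two carbons carries it. Nothing available explains why the bromo has this effect.

As far as these compounds go, whether a different group on the same ring, such as a chlorine, a methoxy group or an amine, would lower the number as well remains open. A reading at a single concentration also leaves the potency of compound 1 and compound 4 unknown.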